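The compounds below may be only part of what the source reports. "The series", "measured", "known", "first", "only" and "open" are said of these compounds alone.

Compound 1 `Cc1ccc2c(Cc3nn4c(C=O)c(-c5ccc(Cl)cc5)nc4s3)coc2c1`: 24.3% in a functional assay on the whole organism (strain Wistar albino) for inhibition, with Rattus norvegicus as the target, read by paw edema, with a stated time of 2 h, at a dose of 100 mg/kg by the oral route; a lower number here means less inhibition, a higher number more inhibition at the dose given (going by the name of the read-out). Compound 2 `Cc1ccc2c(Cc3nn4c(/C=N/O)c(-c5ccc(Cl)cc5)nc4s3)coc2c1`: 11.2%.

For the measured compounds named here, compound 2 stands lowest of the two numbers measured so far, the nearest being compound 1, and the gap between them is the step of a number 13.1 percentage points lower from compound 1 to compound 2 (beyond the scatter). Compound 3 `Cc1ccc2c(Cc3nn4c(C#N)c(-c5ccc(Cl)cc5)nc4s3)coc2c1` is not yet measured; it differs from compound 2 in one place: a group of 2 heavy atoms (1 carbon, 1 nitrogen; no ring) in place of a group of 3 heavy atoms (1 carbon, 1 nitrogen, 1 oxygen; no ring), on an aromatic carbon. Going by the values given here, the only measured step touching this position is a number 13.1 percentage points lower from compound 1 to compound 2 (beyond the scatter), where a two-atom group gave way to a three-atom one. Going back to a two-atom group, cyano, is expected to move the number upward again, by about a number 9.8 percentage points higher from compound 2 to compound 3 (within the scatter). Compound 3 is therefore estimated at 21%, within 9% to 33%.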

Compound 3, a percentage reported as inhibition, in the whole organism at one dose (the size of the read-out at that dose, not a potency): 28%
The estimate for compound 3 lay 7 percentage points below the measured number; the measured number falls inside the stated range.
By their numbers in this assay, from the lowest: compound 2; then compounds 1 and 3 (each within the scatter of the next).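

In this assay, cyano in place of the group of 3 heavy atoms gives a number 16.8 percentage points higher from compound 2 to compound 3 (beyond the scatter), so this position can carry a higher number again once that group is gone. Cyano in place of formyl gives a number 3.7 percentage points higher from compound 1 to compound 3 (within the scatter), so these two groups cannot be told apart here, and only the group in compound 2 stands apart. Nothing available explains why the numbers fall this way. As far as these compounds go, whether an amine, a carboxylic acid or a longer chain at this place would match cyano and formyl stays open. From the compounds shown here alone, how these compounds compare at other doses and times also stays open.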